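The source may hold more compounds than are shown below. What is called first, only, known or untested is meant among the compounds shown, and "the series" means these compounds.

Series notes. All four members share one core; compound 1 `CN(CC1CCN(CCCc2c[nH]c3ccc(-n4cnnc4)cc23)CC1)C(=O)Nc1ccccc1`, compound 2 `C[C@@H](NC1CCN(CCCc2c[nH]c3ccc(-n4cnnc4)cc23)CC1)c1ccccc1` and compound 3 `CC(=O)Nc1ccc([C@@H](C)NCC2CCN(CCCc3c[nH]c4ccc(-n5cnnc5)cc34)CC2)cc1` differ only in the group carried at the far end of that core. In an assay on CHO cells for displacement of a labelled ligand from 5-hydroxytryptamine receptor 1D (Homo sapiens) (a higher number here means a weaker inhibitor, a lower number a stronger inhibitor), compound 1 gives 5.9 nM, compound 2 gives 0.4 nM and compound 3 gives 1.5 nM. Compound 3 thus holds the second highest of the three numbers: its nearest neighbour is compound 2, with a lower number at a gap beyond the scatter, and the furthest is compound 1, with a higher number, also beyond the scatter. Compound 4 `c1ccc2c(c1)CCC2NCC1CCN(CCCc2c[nH]c3ccc(-n4cnnc4)cc23)CC1` is the next member and has not been measured. It differs from compound 3 in one place: 2,3-dihydro-1H-inden-1-yl in place of 1-(4-acetamidophenyl)ethyl on an amine nitrogen. Among the compounds with values here, no step between measured compounds isolates this change, so its size cannot be read from the set; the values of compound 2 and compound 3 show only that the smaller group in compound 2 goes with the lower number. For compound 4 a step in this assay no larger than the scatter is expected, leaning if anything toward a lower number, a 1.5-fold lower number from compound 3 to compound 4 (0.18 log units; within the scatter). The estimate for compound 4 in this assay is 1 nM, with a range from 0.3 nM to 3.5 nM.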

Compound 4, half-maximal inhibitory concentration: 1.1 nM
For compound 4 the middle estimate is 1.1-fold (0.04 log units) below the measured one; low and high end bracket the measured number.
By their numbers in this assay, from the lowest: compound 2; then compounds 4 and 3 (each within the scatter of the next); then compound 1.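

In this assay, a 1.4-fold lower number from compound 3 to compound 4 (0.13 log units; within the scatter) shows that on this amine nitrogen, 2,3-dihydro-1H-inden-1-yl can replace 1-(4-acetamidophenyl)ethyl without a change beyond the scatter, although the entering group has no hydrogen-bond donor or acceptor and the leaving group has one of each. The other two steps, a 2.8-fold higher number from compound 2 to compound 4 (0.44 log units; beyond the scatter) and a 5.4-fold lower number from compound 1 to compound 4 (0.73 log units; beyond the scatter), lie beyond the scatter, but each replaces a larger stretch of the side chain, so neither can be assigned to the 2,3-dihydro-1H-inden-1-yl group alone. No data on the cause of any of these steps are at hand.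

The compounds shown do not separate the loss of the acetamido group from the closing of the five-membered ring. Also open, going by these compounds, is whether a carboxylic acid or an amine on the six-membered aromatic ring of the 2,3-dihydro-1H-inden-1-yl group would leave the number unchanged.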